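Chloro in place of ethyl: an expected step

This account rests on a few compounds, and the source may have more. Where it says the series, first, only, none or still open, it means among the compounds named here.

Compound 1 `Cc1ccc(C#Cc2cncnc2)cc1`: 3300 nM
Compound 2 `CCc1ccc(C#Cc2cncnc2)cc1`: 18800 nM

In an in vitro assay on HEK293-A cells with metabotropic glutamate receptor 5 (Rattus norvegicus) as the target (a higher number here means that more compound is needed for the effect, a lower number that less compound is needed), compound 2 stands highest of the two numbers, a position reached by a 5.7-fold higher number from compound 1 to compound 2 (0.76 log units; beyond the scatter). Compound 3 `Clc1ccc(C#Cc2cncnc2)cc1` has not yet been measured. It differs from compound 2 by chloro in place of ethyl on an aromatic carbon. Among the measured compounds shown here, only one measured step bears on this change, and only in part: a 5.7-fold higher number from compound 1 to compound 2 (0.76 log units; beyond the scatter) shows that the number in this assay rose when ethyl replaced methyl, so the departure of the ethyl is expected to bring the number in this assay back down by a modest amount, while no measured pair shows what a chloro substituent adds or takes away. The step from compound 2 to compound 3 is therefore estimated as a 7.5-fold lower number from compound 2 to compound 3 (0.88 log units; beyond the scatter). Compound 3 is expected at 2500 nM, with a range from 600 nM to 10000 nM.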

Compound 3, half-maximal effective concentration: 3900 nM
Compound 3: middle estimate off by 1.6-fold (0.19 log units), on the low side, within the range that was stated.
By their numbers in this assay, from the lowest: compounds 1 and 3 (each within the scatter of the next); then compound 2.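

In this assay, the higher number seen with ethyl at this place, para to a group of 8 heavy atoms, is not shared by chloro (a 4.8-fold lower number from compound 2 to compound 3 (0.68 log units; beyond the scatter)). Compound 3 cannot be told apart from compound 1 (a 1.2-fold higher number from compound 1 to compound 3 (0.07 log units; within the scatter)), so a single chlorine and a methyl group read alike here, and among these three compounds only the ethyl of compound 2 stands apart, beyond the scatter from both others. Nothing available explains why ethyl differs from these two groups.

As far as these compounds go, it remains open whether a longer chain such as propyl would go further in the direction of ethyl, or whether an amine or a methoxy group at this place would read like chloro and methyl. Also open, from the compounds shown here alone, is whether any group on this carbon can bring the number clearly under the level shared by compound 1 and compound 3.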